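Swapping an Alkyne for a Cyclopropyl on a Nucleoside

A few compounds are considered here, and "the series" means these few. Any claim that something is new, unique, unknown or untested is made for them only; others in the source may bear on it.

Of the compounds shown here, two have been tested so far in a functional assay on L1210 cells (Mus musculus), read by MTT assay; on this read-out higher numbers stand for weaker inhibition and lower numbers for stronger inhibition. Compound 1, `C#C[C@@H]1[C@@H](O)[C@H](n2ccc(=O)[nH]c2=O)O[C@@H]1CO`, gives a result that is a limit of the assay rather than a number: in this assay compound 1 reads > 350000 nM. That limit, (the limit of > 350000 nM in this assay, at which 1 of the 2 values shown sits), belongs to compound 1 alone. Going by the values given here, compound 2, `CCC#C[C@@]1(O)[C@@H](CO)O[C@@H](n2ccc(N)nc2=O)[C@@H]1O`, is the only compound with a measured number; in this assay compound 2 gives 129000 nM. Among the compounds with values here, compound 2 therefore stands as the single anchor for any comparison, and its number points to weak inhibition.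

Compound 3, `Nc1ccn([C@@H]2O[C@H](CO)[C@](O)(C3CC3)[C@H]2O)c(=O)n1`, differs from compound 2 in one place: cyclopropyl in place of but-1-yn-1-yl on a saturated ring carbon. Within the data shown here, no measured pair in this set changes a group on that saturated ring carbon, so no measured step shows how large an effect such a swap can have here. The change is expected to shift the number only modestly, within or close to the scatter. Compound 3 is expected to give 200000 nM in this assay, with a range from 40000 nM to 1000000 nM. The expected step is a 1.6-fold higher number from compound 2 to compound 3 (0.19 log units; within the scatter).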

Compound 3, half-maximal inhibitory concentration: > 350000 nM
Compound 3 gave a limit, no number (the forecaster's own chance of this, stated with the estimate: 40%); middle value at least 1.7-fold (0.24 log units) from the limit.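

In this assay, going by these compounds alone, cyclopropyl in place of but-1-yn-1-yl on a saturated ring carbon gives an at least 2.7-fold higher number from compound 2 to compound 3 (0.43 log units; beyond the scatter), the first measured step at this position. This shows that the read-out responds to what sits on this carbon, and that this swap moves it towards weaker inhibition, by more than repeated measurements would normally scatter. The full size of the step stays unknown because compound 3 gives a limit of the assay rather than a number, so the step shows only the smallest change consistent with that limit: the limit of > 350000 nM in this assay, at which 2 of the 3 values shown sit.

With a single pair, the data cannot say whether the difference follows from the triple bond, the ring or the change in chain length, and a plain propyl chain, a longer alkyne or an amine on this carbon would be needed to separate these possibilities. On these data alone, it also remains open whether any group here could bring the number far below that of compound 2, which itself points to weak inhibition.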